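The source may report more compounds than this note shows. Statements on the series, on what has been measured and on what is new or still open speak of the compounds shown alone.

Measured in a functional assay for antagonist activity at transient receptor potential cation channel subfamily V member 1 (Homo sapiens), read by FLIPR; a higher number here means a weaker inhibitor, a lower number a stronger inhibitor:
compound 1, `N#Cc1ccc(NC(=O)c2ccc(-c3ncccc3C(F)(F)F)cc2)cc1`, gives 417 nM.
compound 2, `Cc1cccnc1-c1ccc(C(=O)Nc2ccc(C(F)(F)F)cc2)cc1`, gives 65 nM.
compound 3, `CC(C)(C)c1ccc(NC(=O)c2ccc(-c3ncccc3NS(C)(=O)=O)cc2)cc1`, gives 152 nM.

Compound 3 stands second highest of the three numbers in this assay. Its nearest neighbour is compound 2, whose number is lower by a step beyond the usual scatter; compound 1 lies further off with a higher number, again beyond the scatter. Compound 3 differs from each of the other two in more than one place, so no single structural step can be read off from these three.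

Compound 4, `CN(C)Cc1cccnc1-c1ccc(C(=O)Nc2ccc(C(C)(C)C)cc2)cc1`, is not yet measured. It differs from compound 3 in one place: (dimethylamino)methyl in place of methanesulfonamido on an aromatic carbon. Among the compounds with values here, no measured pair isolates this exchange, so its size has to be guessed rather than read from a known step.

With no anchor for the exchange, the step of a 1.3-fold higher number from compound 3 to compound 4 (0.12 log units; within the scatter) is expected to be small and in no settled direction, quite possibly within the scatter. Compound 4 is therefore estimated at 200 nM in this assay, with a range from 60 nM to 700 nM.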

Compound 4, half-maximal inhibitory concentration: 746 nM
For compound 4 the middle estimate is 3.7-fold (0.57 log units) below the measured one; measured number outside the range, above it.
By their numbers in this assay, from the lowest: compound 2; then compound 3; then compounds 1 and 4 (each within the scatter of the next).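

In this assay, the position on the aromatic carbon ortho to a large group, two atoms from the ring nitrogen, proves sensitive to its substituent: (dimethylamino)methyl in place of methanesulfonamido gives a 4.9-fold higher number from compound 3 to compound 4 (0.69 log units; beyond the scatter), making compound 4 the weaker inhibitor. Within the data shown here, this is the first step that isolates a single place, and it shows that this position alone can shift inhibition beyond the scatter. Heavy-atom, hydrogen-bond donor and hydrogen-bond acceptor counts all change in this one exchange, and no measurement bears on which feature, if any, accounts for the step.

On these data alone, it remains open whether an acetamido, hydroxymethyl or primary aminomethyl group at this position would sit closer to compound 3 or compound 4. Also unresolved is whether the step keeps its size with a trifluoromethyl or nitrile group in place of tert-butyl.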